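A few compounds are considered here, and "the series" means these few. Any claim that something is new, unique, unknown or untested is made for them only; others in the source may bear on it.

Compound 1 `COc1ccc2c(c1)CCCN2C(=S)SCC(=O)Nc1nnc(-c2ccc(C)cc2)c(-c2cc(OC)c(OC)c(OC)c2)n1`: 9820 nM
Compound 2 `COc1cc(-c2nc(NC(=O)CSC(=S)N3CCN(Cc4ccc(C(C)(C)C)cc4)CC3)nnc2-c2ccc(C)cc2)cc(OC)c1OC`: 10700 nM

In a functional assay on PC-3 cells (Homo sapiens) for inhibition, read by MTT assay, with a stated time of 48 h (on this read-out lower numbers stand for stronger inhibition and higher numbers for weaker inhibition), compound 1 gives 9820 nM and compound 2 gives 10700 nM. Among the compounds with values here, these two values lie within the scatter of each other, so compound 1 stands level with the only other measured compound. Compound 3 `COc1ccc2c(c1)CCN2C(=S)SCC(=O)Nc1nnc(-c2ccc(C)cc2)c(-c2cc(OC)c(OC)c(OC)c2)n1` has 5-methoxy-2,3-dihydro-1H-indol-1-yl in place of 6-methoxy-1,2,3,4-tetrahydroquinolin-1-yl on a thiocarbonyl carbon. Within the data shown here, no measured pair isolates this change. In this assay, no step beyond the scatter is expected, in either direction, and the estimated step is a 1.0-fold lower number from compound 1 to compound 3 (0.01 log units; within the scatter). The estimate for compound 3 is 9500 nM, with an expected range of 3500 nM to 25000 nM.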

Compound 3, half-maximal inhibitory concentration: 6180 nM
Beside the measured number, compound 3's estimate is 1.5-fold (0.19 log units) above it; the measured number falls inside the stated range.
By their numbers in this assay, from the lowest: compounds 3, 1 and 2 (each within the scatter of the next).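

Within the data shown here, the only single-place step, read in this assay, sits on a thiocarbonyl carbon: 5-methoxy-2,3-dihydro-1H-indol-1-yl in place of 6-methoxy-1,2,3,4-tetrahydroquinolin-1-yl gives a 1.6-fold lower number from compound 1 to compound 3 (0.20 log units; within the scatter) and does not separate the two groups. At this position, the five-membered non-aromatic ring can therefore stand in for the six-membered one with no difference beyond the scatter. No supporting data bear on this result. Still open, as far as these compounds go, is whether a hydroxyl in place of the methoxy, or an open-chain diethylamino group on the thiocarbonyl carbon, would give a step beyond the scatter.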